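Removing the Sulfamide Cap from a Hydroxamate Inhibitor

The compounds below may be only part of what the source reports. "The series", "measured", "known", "first", "only" and "open" are said of these compounds alone.

Compound 1, `CNC(=O)[C@H](CCCNC(=O)N1CCOCC1)NC(=O)[C@H](CCCc1ccccc1)[C@@](C)(O)C(=O)NO`: 4 nM
Compound 2, `CNC(=O)[C@H](CCCNS(=O)(=O)N(C)C)NC(=O)[C@H](CCCc1ccccc1)[C@@](C)(O)C(=O)NO`: 2 nM

Among the measured compounds shown here, in an assay on isolated protein for binding affinity to matrix metalloproteinase-9 (Homo sapiens) (on this read-out higher numbers stand for weaker inhibition and lower numbers for stronger inhibition), compound 2 gives the lower of the two numbers; its only neighbour is compound 1, and a 2.0-fold lower number from compound 1 to compound 2 (0.30 log units; within the scatter), so the two cannot be told apart. Compound 3 is `CNC(=O)[C@H](CCCN)NC(=O)[C@H](CCCc1ccccc1)[C@@](C)(O)C(=O)NO`; the change is hydrogen in place of dimethylsulfamoyl on an amine nitrogen. For the measured compounds named here, the one measured step only swaps one cap on that nitrogen for another and stayed within the scatter; no step removes the cap altogether, so the data bear only loosely on this change. With nothing pointing to a gain, compound 3 is expected to give 8 nM (range 2 nM to 40 nM), which means an estimated 4.0-fold higher number from compound 2 to compound 3 (0.60 log units; beyond the scatter).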

Compound 3, inhibition constant: 5 nM
Beside the measured number, compound 3's estimate is 1.6-fold (0.20 log units) above it; measured number inside the range.
By their numbers in this assay, from the lowest: compounds 2, 1 and 3 (each within the scatter of the next, the first and the last beyond it).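

With the cap gone altogether, this nitrogen becomes a free amine, and in this assay there is a 2.5-fold higher number from compound 2 to compound 3 (0.40 log units; beyond the scatter) and a 1.3-fold higher number from compound 1 to compound 3 (0.10 log units; within the scatter) so the result depends on which cap is compared. A bare amino group therefore keeps the number in the same low range, so neither the dimethylsulfamoyl nor the (morpholin-4-yl)carbonyl cap is needed for strong inhibition here. Nothing measured alongside these numbers accounts for them. Still open, going by these compounds, is how a simple acetyl group on this nitrogen, a carboxylic acid in place of the amine, or a longer chain carrying the amine would compare.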